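Removing the methylsulfonyl group from an inactive amide

The compounds below may be only part of what the source reports. "The series", "measured", "known", "first", "only" and "open" are said of these compounds alone.

Compound 3 `CS(=O)(=O)c1ccc(C(=O)Nc2ccc(Cl)c(-c3nnc4c(Cl)cccn34)c2)cc1` carries a 4-(methylsulfonyl)phenyl amide on the shared core. In a functional assay on A549 cells (Homo sapiens) for antiproliferative activity, read by MTT assay, with a stated time of 72 h (on this read-out lower numbers stand for stronger inhibition and higher numbers for weaker inhibition), compound 3 gives > 100000 nM, which is a limit of the assay and not a number. Compound 1 `O=C(Nc1ccc(Cl)c(-c2nnc3c(Cl)cccn23)c1)c1ccccn1` carries a pyridin-2-yl amide instead; in this assay compound 1 gives > 100000 nM, again a limit. Compound 2 `O=C(Nc1ccc(Cl)c(-c2nnc3c(Cl)cccn23)c1)c1cccnc1` carries a pyridin-3-yl amide, and in this assay compound 2 gives > 100000 nM, also a limit. The steps leading to compound 3, namely a step that the two limits leave unreadable from compound 1 to compound 3 and a step that the two limits leave unreadable from compound 2 to compound 3, cannot be sized, since all three values sit at the same limit (the limit of > 100000 nM in this assay, at which 3 of the 3 values shown sit). Compound 4 `O=C(Nc1ccc(Cl)c(-c2nnc3c(Cl)cccn23)c1)c1ccccc1` is reached by the change (hydrogen in place of methylsulfonyl on an aromatic carbon). Going by the values given here, the measured steps give no direction or size to carry over: three different amide groups all left the activity beyond the reach of the assay, and no measured compound in this set shows a readable number. The expected step is therefore a step that the limit leaves unreadable from compound 3 to compound 4. Compound 4 is estimated at 150000 nM, with a range from 30000 nM to 500000 nM, and most probably it will again be reported only as a limit.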

Compound 4, half-maximal inhibitory concentration: 76900 nM
Beside the measured number, compound 4's estimate is 2.0-fold (0.29 log units) above it; the measured number falls inside the stated range.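

In this assay, going by these compounds alone, compound 4, with hydrogen in place of methylsulfonyl, gives 76900 nM, the first readable number in this set, so the bare phenyl amide brings activity just within reach of the assay. Removing the methylsulfonyl group gives an at least 1.3-fold lower number from compound 3 to compound 4 (0.11 log units; that floor lies within the scatter), and the comparisons with the two pyridine amides read the same way, with an at least 1.3-fold lower number from compound 2 to compound 4 (0.11 log units; that floor lies within the scatter) and an at least 1.3-fold lower number from compound 1 to compound 4 (0.11 log units; that floor lies within the scatter). These are only floors and the steps among the other three compounds stay unreadable, since their values are all limits: the limit of > 100000 nM in this assay, at which 3 of the 4 values shown sit.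

Going by these compounds, whether a small group such as an amine or a methoxy at this place on the phenyl ring would lower the number further remains open. So does the true size of the step from the methylsulfonyl group to hydrogen.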